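The compounds below may be only part of what the source reports. "The series", "measured", "known", "first", "only" and "open" are said of these compounds alone.

Measured compounds in an ADME assay on a cell-free system (plasma, Homo sapiens) for metabolic stability, with Plasma (Rattus norvegicus) as the target, read by HPLC, at pH 7.4; on this read-out lower numbers stand for a shorter-lived compound and higher numbers for a longer-lived compound:
Compound 1 `CC(=O)Oc1ccccc1C(=O)O[C@H]1CO[C@H]2[C@@H]1OC[C@H]2OC(=O)c1snnc1C` gives 0.0642 h.
Compound 2 `CC(=O)Oc1ccccc1C(=O)O[C@H]1CO[C@H]2[C@@H]1OC[C@H]2OC(=O)c1cccc(O)c1` gives 0.0183 h.
Compound 3 `CCCCC(=O)O[C@@H]1CO[C@H]2[C@@H]1OC[C@@H]2OC(=O)c1ccccc1OC(C)=O` gives 0.0198 h.

Compound 2 holds the lowest of the three numbers in this assay, but compound 3 sits within the scatter of it, as a 1.1-fold higher number from compound 2 to compound 3 (0.03 log units; within the scatter) shows, and only compound 1 stands clearly apart, as a 3.5-fold lower number from compound 1 to compound 2 (0.55 log units; beyond the scatter) shows.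

Compound 4 `CC(=O)Oc1ccccc1C(=O)O[C@H]1CO[C@H]2[C@@H]1OC[C@H]2OC(=O)c1ccc(-c2ccccc2)cc1` differs from compound 2 in one place: 4-phenylphenyl in place of 3-hydroxyphenyl on a carbonyl carbon. Among the measured compounds shown here, the steps that bear on this are those that exchange the group on the same carbonyl carbon, a 3.5-fold lower number from compound 1 to compound 2 (0.55 log units; beyond the scatter), a 3.2-fold lower number from compound 1 to compound 3 (0.51 log units; beyond the scatter) and a 1.1-fold higher number from compound 2 to compound 3 (0.03 log units; within the scatter). Of these, only the exchange away from 4-methyl-1,2,3-thiadiazol-5-yl moved the number beyond the scatter; 3-hydroxyphenyl and butyl gave numbers within the scatter of each other. For the measured compounds named here, a fourth group at this position therefore is expected to land near compound 2, with at most a small rise, since no measured step points to a larger move in either direction. For compound 4 the estimate in this assay is 0.025 h, with a range from 0.01 h to 0.065 h. The step this estimate implies is a 1.4-fold higher number from compound 2 to compound 4 (0.14 log units; within the scatter), which is expected to stay within the scatter.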

Compound 4, half-life: > 0.333 h
Compound 4: no number, only a limit; the forecaster's own chance of this, stated with the estimate: 5%; middle value at least 13-fold (1.12 log units) from the limit.
By their numbers in this assay, from the lowest: compounds 2 and 3 (each within the scatter of the next); then compound 1. At a limit, above all of these: compound 4.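

In this assay compound 4 carries no number, only a limit: the limit of > 0.333 h in this assay, at which 1 of the 4 values shown sits. Among the compounds shown here, the group on this carbonyl carbon can move the half-life much further than the earlier compounds suggested, where 3-hydroxyphenyl and butyl did not separate, with a 1.1-fold higher number from compound 2 to compound 3 (0.03 log units; within the scatter). With 4-phenylphenyl in this place the series shows an at least 18-fold higher number from compound 2 to compound 4 (1.25 log units; beyond the scatter) and an at least 16-fold higher number from compound 3 to compound 4 (1.22 log units; beyond the scatter), and the new group also clears 4-methyl-1,2,3-thiadiazol-5-yl, the group of the longest-lived earlier compound, with an at least 5.1-fold higher number from compound 1 to compound 4 (0.71 log units; beyond the scatter).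

The single step both adds a second aromatic ring and removes the hydroxyl, so the compounds shown leave open which of the two goes with the rise; a plain phenyl group on this carbonyl carbon would separate them. As far as these compounds go, the true size of the rise also stays open, as does the outcome with an amine-bearing phenyl group here.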